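The source may report more compounds than this note shows. Statements on the series, on what has been measured and on what is new or still open speak of the compounds shown alone.

Measured compounds in the series:

- compound 1 `Cc1ccc(-n2cc(COc3cccc4cnc(Nc5cccc(Cl)c5)nc34)nn2)c([N+](=O)[O-])c1`: 7000 nM
- compound 2 `Clc1cccc(Nc2ncc3cccc(OCc4cn(-c5cc(Cl)cc(Cl)c5)nn4)c3n2)c1`: 8000 nM
- compound 3 `COc1cccc(-n2cc(COc3cccc4cnc(Nc5cccc(Cl)c5)nc34)nn2)c1`: 10000 nM

In a functional assay on PC-3 cells (Homo sapiens) for cytotoxicity, read by cell counting, with a stated time of 48 h (a lower number here means a stronger inhibitor, a higher number a weaker inhibitor), compound 1 has the lowest of the three numbers, but the spread is small. The nearest is a 1.1-fold higher number from compound 1 to compound 2 (0.06 log units; within the scatter), the furthest is a 1.4-fold higher number from compound 1 to compound 3 (0.15 log units; within the scatter), and between the other two compounds the gap is a 1.3-fold higher number from compound 2 to compound 3 (0.10 log units; within the scatter). None of these steps rises above the scatter, so no ordering of the three compounds is claimed; they read as equivalent in this assay.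

Compound 4 `COc1ccccc1-n1cc(COc2cccc3cnc(Nc4cccc(Cl)c4)nc23)nn1` is not yet measured. Its change from compound 1 is 2-methoxyphenyl in place of 4-methyl-2-nitrophenyl on an aromatic nitrogen.

All three measured steps bear on this change: each of them replaces the aryl group on the aromatic nitrogen of the triazole-bearing position, and each stays within the scatter. Nothing in the data singles out the group that enters in compound 4 as behaving differently from the groups already tried, so no step beyond the scatter is expected in this assay, in either direction.

The expected step is a 1.1-fold higher number from compound 1 to compound 4 (0.06 log units; within the scatter). The estimate for compound 4 is therefore 8000 nM, with a range from 3500 nM to 18000 nM, centred close to the values of compounds 1, 2 and 3.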

Compound 4, half-maximal inhibitory concentration: 8000 nM
Compound 4: the middle estimate sits on the measured number at the digits printed, and the stated range covers the measured number.
By their numbers in this assay, from the lowest: compounds 1, 2, 4 and 3 (each within the scatter of the next).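

In this assay the 2-methoxyphenyl group on the aromatic nitrogen gives no step beyond the scatter against any of the three earlier groups: against 4-methyl-2-nitrophenyl (a 1.1-fold higher number from compound 1 to compound 4 (0.06 log units; within the scatter)), against 3,5-dichlorophenyl (no change at the digits printed from compound 2 to compound 4 (within the scatter)) and against 3-methoxyphenyl (a 1.3-fold lower number from compound 3 to compound 4 (0.10 log units; within the scatter)). The last pair is new in kind, since 3-methoxyphenyl and 2-methoxyphenyl carry the same methoxy group at two different places on the phenyl ring, and this shift leaves the read-out as flat as the exchanges of whole aryl groups did. No accompanying measurement bears on this result, so the flatness stands as a description of these four compounds only.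

For the compounds shown here, every group at this position so far is a substituted phenyl ring, so it remains open whether a phenyl ring bearing a carboxylic acid or an amine, or a plain alkyl chain in place of the ring, would produce a step beyond the scatter. Going by these compounds, the rest of the molecule is identical in all four compounds, so what changes there would do also remains open.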